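The source may hold more compounds than are shown below. What is called first, only, known or untested is meant among the compounds shown, and "the series" means these compounds.

Measured so far in this series:
compound 1, `S=C(N/N=C/c1ccc2ccccc2n1)Nc1cccc(Br)c1`: 53800 nM
compound 2, `NC(=S)N/N=C/c1nc2ccccc2s1`: > 100000 nM

Among the compounds with values here, in a functional assay on HL-60 cells (Homo sapiens) for antiproliferative activity, read by sulforhodamine B assay, with a stated time of 72 h (on this read-out higher numbers stand for weaker inhibition and lower numbers for stronger inhibition), compound 1 gives 53800 nM, which is the only real number so far. For compound 2 the read-out in this assay is a limit of the assay and not a number, > 100000 nM. The other value shown is therefore (the limit of > 100000 nM in this assay, at which 1 of the 2 values shown sits). Within the data shown here, compound 1 and compound 2 differ in more than one place, so no single step connects them; their two values show only that compound 1 falls inside the measured range while compound 2 does not.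

The next compound, compound 3, `Fc1cccc(NC(=S)N/N=C/c2ccc3ccccc3n2)c1`, is not yet measured in this assay. It differs from compound 1 by fluoro in place of bromo on an aromatic carbon. Among the measured compounds shown here, no measured step of this kind exists, so the expected size of the step in this assay rests on the structural change alone: a small step, probably not beyond the usual scatter, with a modest lean toward weaker inhibition. On that basis compound 3 is expected to give 70000 nM, with a range from 25000 nM to 200000 nM. The step from compound 1 to compound 3 that this estimate implies is a 1.3-fold higher number from compound 1 to compound 3 (0.11 log units; within the scatter).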

Compound 3, half-maximal inhibitory concentration: 43800 nM
Compound 3: the middle estimate sits 1.6-fold (0.20 log units) above what was measured; measured number inside the range.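

In this assay, within the data shown here, the exchange from 3-bromophenyl to 3-fluorophenyl gives the first single-place step, and it reads a 1.2-fold lower number from compound 1 to compound 3 (0.09 log units; within the scatter). At this place, on an aromatic carbon meta to a large group, bromo and fluoro are therefore not told apart by this read-out, and for this pair the identity of the halogen carries no change beyond the scatter. Among these compounds, nothing measured so far gives a reason for this result.

Only these two halogens are shown at this place, so it stays open whether an amine, a carboxylic acid or a longer chain there would move the number beyond the scatter, in either direction. Going by these compounds, compound 2 differs from compound 1 and from compound 3 in more than one place, so what separates it from them cannot be assigned to any single part of the structure, and the contribution of the rest of the shared core remains untested by any single step.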